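A few compounds are considered here, and "the series" means these few. Any claim that something is new, unique, unknown or untested is made for them only; others in the source may bear on it.

Among the compounds with values here, compound 2 `CC(=O)c1ccc(NC(=O)N[C@@H](C)c2ccccc2)cc1` gives 96% in an ADME assay on the whole organism with Oryza sativa as the target, tested at 10 uM (on this read-out higher numbers stand for a weaker effect at the one concentration tested and lower numbers for a stronger effect), and stands highest of the two numbers so far; its nearest neighbour is compound 1 `CCc1ccc(NC(=O)N[C@@H](C)c2ccccc2)cc1`, which gives 91% in this assay, a gap within the scatter. Compound 3 `C[C@H](NC(=O)Nc1ccc(F)cc1)c1ccccc1` is still to be measured. It differs from compound 2 by fluoro in place of acetyl on an aromatic carbon. Within the data shown here, the one step on record, a number 5 percentage points higher from compound 1 to compound 2 (within the scatter), acetyl in place of ethyl on an aromatic carbon, stayed within the scatter, and no measured step involves a fluoro. The step expected a number 4 percentage points lower from compound 2 to compound 3 (within the scatter) is therefore none beyond the scatter. Compound 3 is estimated at 92%, between 80% and 100%.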

Compound 3, a percentage reported as activity, at one concentration (the size of the read-out at that concentration, not a potency): 85%
Compound 3: the middle estimate sits 7 percentage points above what was measured; the range from low to high includes it.
By their numbers in this assay, from the lowest: compounds 3, 1 and 2 (each within the scatter of the next, the first and the last beyond it).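

Within the data shown here, at this position, on an aromatic carbon para to a large group, fluoro in place of acetyl gives the first step beyond the scatter in this assay: a number 11 percentage points lower from compound 2 to compound 3 (beyond the scatter). Fluoro in place of ethyl stays inside it, with a number 6 percentage points lower from compound 1 to compound 3 (within the scatter), so compound 1 cannot be separated from either of the other two. No measured information accounts for the step. Still open, from the compounds shown here alone, is how an amine, a carboxylic acid or a methoxy group at this position would read, and whether any of them would give a number clearly lower than that of compound 3.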